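From isopropyl to cyclopropyl on a sulfonyl sulfur

The source may report more compounds than this note shows. Statements on the series, on what has been measured and on what is new or still open speak of the compounds shown alone.

- Compound 1 `CCOc1cc(S(=O)(=O)CC)ccc1-c1cc(-c2cnnc3c2ncn3CC)ccc1F` gives 3.3
- Compound 2 `CCn1cnc2c(-c3ccc(F)c(-c4ccc(S(C)(=O)=O)cc4OC)c3)cnnc21` gives 2.5
- Compound 3 `CCn1cnc2c(-c3ccc(F)c(-c4ccc(S(=O)(=O)C(C)C)cc4OC)c3)cnnc21` gives 3

In a physicochemical assay for lipophilicity (a lower number here means a more polar compound, a higher number a more lipophilic compound), compound 3 gives 3 and stands within the scatter of compound 1 (at 3.3). Compound 2 gives 2.5, and the gap between that value and compound 3 lies beyond the scatter. Compound 4 `CCn1cnc2c(-c3ccc(F)c(-c4ccc(S(=O)(=O)C5CC5)cc4OC)c3)cnnc21` carries cyclopropyl in place of isopropyl on a sulfonyl sulfur. Among the measured compounds shown here, one measured step bears on this change: a number 0.50 log units higher from compound 2 to compound 3 (beyond the scatter) (isopropyl in place of methyl on a sulfonyl sulfur), which is modest. For the measured compounds named here, no measured compound carries cyclopropyl, so this guide is indirect. In this assay the expected step is small, downward and within the scatter (estimated a number 0.20 log units lower from compound 3 to compound 4 (within the scatter)). For compound 4 the expected value is 2.8 (estimated range 2.5 to 3.1).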

Compound 4, distribution coefficient: 2.7
The estimate for compound 4 lay 0.10 log units above the measured number; measured number inside the range.
By their numbers in this assay, from the lowest: compounds 2, 4, 3 and 1 (each within the scatter of the next, the first and the last beyond it).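

In this assay the change from isopropyl to cyclopropyl on the sulfonyl sulfur gave a number 0.30 log units lower from compound 3 to compound 4 (within the scatter) and the change from methyl to cyclopropyl gave a number 0.20 log units higher from compound 2 to compound 4 (within the scatter) so compound 4 cannot be told apart from either compound. The earlier compounds shown here showed only that methyl and isopropyl at this place differ, with a number 0.50 log units higher from compound 2 to compound 3 (beyond the scatter) and cyclopropyl now falls within the scatter of both. Whether a cyclobutyl group or an amine on the sulfonyl sulfur would fall outside that span stays open, and nothing at hand accounts for where compound 4 falls.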